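Tertiary Alcohol Variant of an Aminopyrimidine Urea Series

The source may hold more compounds than are shown below. What is called first, only, known or untested is meant among the compounds shown, and "the series" means these compounds.

Three compounds have been measured in an assay on isolated protein for inhibition of serine/threonine-protein kinase TNNI3K (Homo sapiens); on this read-out lower numbers stand for stronger inhibition and higher numbers for weaker inhibition:

Compound 1, `CCNc1cc(Oc2ccc(NC(=O)Nc3cccc(C(F)(F)F)c3)cc2)ncn1`: 25 nM
Compound 2, `CCCNc1cc(Oc2ccc(NC(=O)Nc3cccc(C(F)(F)F)c3)cc2)ncn1`: 32 nM
Compound 3, `C[C@@H](O)CNc1cc(Oc2ccc(NC(=O)Nc3cccc(C(F)(F)F)c3)cc2)ncn1`: 63 nM

Compound 3 shows the highest number of the three. Its gap to compound 2 is within the scatter, so the two cannot be ordered, whereas a 2.5-fold higher number from compound 1 to compound 3 (0.40 log units; beyond the scatter) is a modest step beyond the scatter.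

Compound 4, `CC(C)(O)CNc1cc(Oc2ccc(NC(=O)Nc3cccc(C(F)(F)F)c3)cc2)ncn1`, has not been measured. It differs from compound 3 in one place: 1-hydroxy-1-methylethyl in place of 1-hydroxyethyl on a saturated chain carbon bound to a nitrogen on an aromatic ring.

Among the measured compounds shown here, two measured steps bear on this. a 1.3-fold higher number from compound 1 to compound 2 (0.11 log units; within the scatter) shows that adding a methyl along the chain hardly moved the number. a 2.0-fold higher number from compound 2 to compound 3 (0.29 log units; within the scatter) shows that adding the hydroxy also stayed within the scatter. A further methyl on the carbon that already carries the hydroxy is therefore expected to give at most a small change in this assay, perhaps towards a slightly higher number, though a step within the scatter is equally plausible.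

The expected result for compound 4 is 80 nM, with a range from 35 nM to 180 nM, meaning an estimated 1.3-fold higher number from compound 3 to compound 4 (0.10 log units; within the scatter).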

Compound 4, half-maximal inhibitory concentration: 40 nM
The estimate for compound 4 lay 2.0-fold (0.30 log units) above the measured number; the range from low to high includes it.
By their numbers in this assay, from the lowest: compounds 1, 2, 4 and 3 (each within the scatter of the next, the first and the last beyond it).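

In this assay, among the compounds shown here, the change from 2-hydroxypropyl to 2-hydroxy-2-methylpropyl removes the defined stereocentre and gives a 1.6-fold lower number from compound 3 to compound 4 (0.20 log units; within the scatter) and so no step that can be told from the scatter. Set against the chains without a hydroxy, the new chain gives a 1.3-fold higher number from compound 2 to compound 4 (0.10 log units; within the scatter) and a 1.6-fold higher number from compound 1 to compound 4 (0.20 log units; within the scatter) and thus shows, as the earlier compounds did not, that a hydroxy on this chain can be present with no step beyond the scatter from either. No evidence is available that would explain these numbers.

Whether an amine or a carboxylic acid in place of the hydroxy would stay within the scatter of these compounds remains open. So does the effect of a longer chain carrying the hydroxy, and of the opposite stereocentre in the 2-hydroxypropyl chain.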